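A ring swap at the sulfonyl sulfur of compound 2

The compounds below may be only part of what the source reports. "The series", "measured", "known", "first", "only" and "open" are said of these compounds alone.

Measured in an ADME assay (liver) for metabolic stability, with Liver microsome (Homo sapiens) as the target, read by LC-MS, using microsomes and NADPH, with a stated time of 5 min, at 37 degrees C; a lower number here means slower removal, a higher number faster removal of the compound:
- compound 1 `CCn1c([C@@H](C)NS(=O)(=O)c2ccc(C)cc2)nc2ccc(C(F)(F)F)cc21`: > 100 mL.min-1.g-1
- compound 2 `CCn1c([C@@H](C)NS(=O)(=O)c2ccc(CC(C)C)cc2)nc2ccc(C(F)(F)F)cc21`: > 100 mL.min-1.g-1

Neither entry is a number, as each is a limit of the assay. The whole record so far comes down to this: the limit of > 100 mL.min-1.g-1 in this assay, at which 2 of the 2 values shown sit. Compound 2 therefore stands at > 100 mL.min-1.g-1, which is a limit. Within the data shown here, the only measured step is a step that the two limits leave unreadable from compound 1 to compound 2, so it provides no size to carry forward.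

Compound 3 `CCCn1cc(S(=O)(=O)N[C@H](C)c2nc3ccc(C(F)(F)F)cc3n2CC)c(C)n1` keeps the shared core and differs from compound 2 in one place: a group of 9 heavy atoms (7 carbon, 2 nitrogen; one five-membered aromatic ring with 2 hetero atoms) in place of a group of 10 heavy atoms (10 carbon; one six-membered aromatic ring of carbon only), on a sulfonyl sulfur. The 4-isobutylphenyl leaves, and a five-membered aromatic ring with 2 hetero atoms enters on the sulfonyl sulfur. Among the measured compounds shown here, no measured step covers a change of this kind.

The expectation in this assay thus rests on compound 2 at > 100 mL.min-1.g-1, itself a limit. Removal is expected to stay fast, perhaps with a modest step toward slower removal, though no measured step fixes its size. The estimated change is an at least 1.2-fold lower number from compound 2 to compound 3 (0.09 log units; that floor lies within the scatter). For compound 3 the expected value is 80 mL.min-1.g-1, with an estimated range from 30 mL.min-1.g-1 to 200 mL.min-1.g-1.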

Compound 3, intrinsic clearance in microsomes: > 100 mL.min-1.g-1
Compound 3: no number, only a limit; the forecaster's own chance of this, stated with the estimate: 50%; middle value at least 1.2-fold (0.09 log units) from the limit.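

In this assay compound 3 gives > 100 mL.min-1.g-1, which is a limit and not a number. Among these compounds, no step among compound 1, compound 2 and compound 3 can be read, because all three sit at the same limit: the limit of > 100 mL.min-1.g-1 in this assay, at which 3 of the 3 values shown sit. The compounds shown leave open how fast each one is actually removed, and whether the ring swap at the sulfonyl sulfur changes that rate at all.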